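This account rests on a few compounds, and the source may have more. Where it says the series, first, only, none or still open, it means among the compounds named here.

Working notes on the amide series in a functional assay on the whole organism for inhibition, with Rattus norvegicus as the target, read by paw edema, with stated times of 30 min and 3 h, at a dose of 0.28 mmol/kg by the oral route; a lower number here means less inhibition, a higher number more inhibition at the dose given (going by the name of the read-out). Of the compounds shown here, three sharing one core have been measured. Compound 1 `COc1ccc(NC(=O)c2nc(-c3cc(OC)c(OC)c(OC)c3)n(-c3ccc(OC)cc3)n2)cc1` gives 86% in this assay. Compound 2 `COc1ccc(-n2nc(C(=O)Nc3ccc(C)cc3)nc2-c2cc(OC)c(OC)c(OC)c2)cc1` gives 77%. Compound 3 `COc1ccc(-n2nc(C(=O)Nc3ccc(C(F)(F)F)cc3)nc2-c2cc(OC)c(OC)c(OC)c2)cc1` gives 83%. Compound 2 shows the lowest of the three numbers, yet the differences are a number 6 percentage points higher from compound 2 to compound 3 (within the scatter) and a number 9 percentage points lower from compound 1 to compound 2 (within the scatter), so the three compounds stand level in this assay and no ordering among them is supported.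

Compound 4 `COc1ccc(-n2nc(C(=O)Nc3ccccc3)nc2-c2cc(OC)c(OC)c(OC)c2)cc1` has not yet been measured in this assay. Its change from compound 2 is hydrogen in place of methyl on an aromatic carbon. Among the measured compounds shown here, the steps that bear on it are those that also exchange the group on that aromatic carbon: a number 9 percentage points lower from compound 1 to compound 2 (within the scatter) and a number 6 percentage points higher from compound 2 to compound 3 (within the scatter). Exchanging methoxy, methyl and trifluoromethyl at this position thus moved the number only within the scatter in every case, with no direction that holds up. Hydrogen in place of methyl is expected to behave the same way, so the expected step is a number 2 percentage points higher from compound 2 to compound 4 (within the scatter), without a shift beyond the scatter in either direction. The estimate for compound 4 in this assay is therefore 79%, expected to fall between 67% and 90%.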

Compound 4, a percentage reported as inhibition, in the whole organism at one dose (the size of the read-out at that dose, not a potency): 69%
For compound 4 the middle estimate is 10 percentage points above the measured one, and the stated range covers the measured number.
By their numbers in this assay, from the lowest: compounds 4, 2, 3 and 1 (each within the scatter of the next, the first and the last beyond it).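

In this assay, the position on the anilide ring, para to a large group, is no longer silent once its substituent is removed altogether: exchanging one substituent for another had stayed within the scatter, but hydrogen gives a number 14 percentage points lower from compound 3 to compound 4 (beyond the scatter) and also a number 17 percentage points lower from compound 1 to compound 4 (beyond the scatter) as steps beyond it. The trifluoromethyl and methoxy compounds therefore both stand apart from the unsubstituted phenylcarbamoyl compound, even though these two groups could not be told apart from each other, so carrying a group here matters more than which of these two it is. Compound 2 goes against this reading, since a number 8 percentage points lower from compound 2 to compound 4 (within the scatter) stays within the scatter and the loss of methyl alone cannot be separated from no change, and no supporting measurement bears on the reason for these steps.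

The compounds shown leave open whether an amine, a carboxylic acid, a hydroxyl or a longer chain such as ethyl on this carbon would read with compound 1 and compound 3 or with compound 4. These numbers also come from a single dose, so they leave open whether the gaps would persist at other doses.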